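This account rests on a few compounds, and the source may have more. Where it says the series, first, only, none or still open, it means among the compounds named here.

In a functional assay on PA-1 cells (Homo sapiens) for cytotoxicity, read by MTT assay, with a stated time of 4 h (on this read-out higher numbers stand for weaker inhibition and lower numbers for stronger inhibition), compound 1 (`COC(=O)C1=CO[C@@H](O[C@@H]2O[C@H](COC(c3ccccc3)(c3ccccc3)c3ccccc3)[C@@H](O)[C@H](O)[C@H]2O)[C@@H]2[C@@H](C)[C@@H](O)C[C@H]12`) gives 0.65 ug/mL, a clear number that shows what a compound of this family can do in the test. Compound 2 (`COC(=O)C1=CO[C@@H](O[C@@H]2O[C@H](CO)[C@@H](OC(C)=O)[C@H](OC(C)=O)[C@H]2OC(C)=O)[C@@H]2[C@@H](C)[C@@H](OC(C)=O)C[C@H]12`) is reported as "not active" (no number reported). It therefore has no single number, and its place can only be described in words, as a compound that gave no measurable effect here. Compound 3 (`CCC(=O)OC[C@H]1O[C@@H](O[C@@H]2OC=C(C(=O)OC)[C@H]3C[C@H](OC(C)=O)[C@H](C)[C@@H]23)[C@H](OC(C)=O)[C@@H](OC(C)=O)[C@@H]1OC(C)=O`) differs from compound 2 in one place: propanoyl in place of hydrogen on an oxygen on a saturated carbon. Put simply, a propanoyl takes the place of hydrogen on an oxygen on a saturated carbon, turning hydroxymethyl into (propanoyloxy)methyl, while the rest of the molecule stays the same. Among the measured compounds shown here, no measured pair in this small set shows what such a change does, so any forecast rests on compound 2 alone. Since compound 2 is reported as "not active" (no number reported), no step beyond the scatter is expected in this assay, and the most likely outcome is another report without a number. If a number does appear, the estimated value for compound 3 is 20 ug/mL, within an expected range of 4 ug/mL to 100 ug/mL.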

Compound 3, half-maximal inhibitory concentration: 1.24 ug/mL
For compound 3 the middle estimate is 16-fold (1.21 log units) above the measured one; measured number below the stated range.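

In this assay, among the compounds shown here, compound 3 gives 1.24 ug/mL while compound 2 is reported as not active without a number, so no step in size can be read between compound 2 and compound 3. Nothing available explains this result. The compounds shown leave open how large a change the swap from hydroxymethyl to (propanoyloxy)methyl makes on this read-out.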